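This account rests on a few compounds, and the source may have more. Where it says the series, first, only, none or still open, it means among the compounds named here.

Compound 1, `Cc1cc(-c2ccc(C#N)cc2)cc(C)c1Nc1ccnc(Nc2ccc(C#N)cc2)n1`: 2080 nM
Compound 2, `Cc1cc(-c2ccc(F)cc2)cc(C)c1Nc1ccnc(Nc2ccc(C#N)cc2)n1`: 4170 nM
Compound 3, `Cc1cc(-c2cc(F)cc(F)c2)cc(C)c1Nc1ccnc(Nc2ccc(C#N)cc2)n1`: 3910 nM

Three compounds that share a common core and differ only in the outer aromatic ring have been tested in an ADME assay on MT4 cells (Homo sapiens) for cytotoxicity, read by MTT assay, with a stated time of 4 days; on this read-out lower numbers stand for higher toxicity in this test and higher numbers for lower toxicity in this test. Compound 2 gives the highest of the three numbers, but none of the gaps is large: the step of a 1.1-fold lower number from compound 2 to compound 3 (0.03 log units; within the scatter) and the step of a 2.0-fold higher number from compound 1 to compound 2 (0.30 log units; within the scatter) both stay within the usual scatter, so the three compounds cannot be told apart on this read-out.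

Compound 4, `Cc1cc(-c2ccc(C(F)(F)F)cc2)cc(C)c1Nc1ccnc(Nc2ccc(C#N)cc2)n1`, is the next compound in this series. Its difference from compound 2 is trifluoromethyl in place of fluoro on an aromatic carbon. The changes already measured are all of the same kind, swaps of a small group on that outer ring, and each of them, a 2.0-fold higher number from compound 1 to compound 2 (0.30 log units; within the scatter), a 1.9-fold higher number from compound 1 to compound 3 (0.27 log units; within the scatter) and a 1.1-fold lower number from compound 2 to compound 3 (0.03 log units; within the scatter), left the number essentially where it was. For the measured compounds named here, nothing measured so far suggests that a change at this position moves the result in either direction. The step to compound 4 is therefore expected to be no larger than the scatter, a 1.2-fold lower number from compound 2 to compound 4 (0.08 log units; within the scatter). Compound 4 is accordingly estimated to give 3500 nM in this assay, with a likely range from 1500 nM to 8000 nM.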

Compound 4, half-maximal cytotoxic concentration: 4160 nM
For compound 4 the middle estimate is 1.2-fold (0.08 log units) below the measured one; low and high end bracket the measured number.
By their numbers in this assay, from the lowest: compounds 1, 3, 4 and 2 (each within the scatter of the next).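

In this assay, placing the larger trifluoromethyl in place of fluoro on this aromatic carbon, para to a large group, gives a 1.0-fold lower number from compound 2 to compound 4 (0.00 log units; within the scatter) and leaves the two compounds indistinguishable on this read-out. The comparisons with the other two outer rings give the same picture: one is a 1.1-fold higher number from compound 3 to compound 4 (0.03 log units; within the scatter) and the other is a 2.0-fold higher number from compound 1 to compound 4 (0.30 log units; within the scatter), so trifluoromethyl also cannot be separated from the 3,5-difluorophenyl or 4-cyanophenyl compounds, and all four compounds now sit within the scatter of their neighbours in the ranking. No measurement available here accounts for this flat result.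

The compounds shown cover only fluoro, cyano and trifluoromethyl variations of the outer ring, so it remains open whether the number would also stay put with an amine, a carboxylic acid or a longer alkyl chain at this position. From the compounds shown here alone, it also remains open whether any change at this position can move the number beyond the scatter, since every step seen so far stays within it.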